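Adding a Third Methoxy Group to a Nitroimidazole Oxadiazole

The compounds below may be only part of what the source reports. "The series", "measured", "known", "first", "only" and "open" are said of these compounds alone.

Compound 1, with structure `Cc1ncc([N+](=O)[O-])n1CCSc1nnc(-c2ccccc2)o1`, was tested in a functional assay on MCF7 cells (Homo sapiens) for cytotoxicity, read by MTT assay, with a stated time of 48 h (a higher number here means a weaker inhibitor, a lower number a stronger inhibitor), and gives 20500 nM. Compound 2, with structure `COc1ccc(-c2nnc(SCCn3c([N+](=O)[O-])cnc3C)o2)cc1`, gives 10600 nM in this assay. The difference between them is methoxy in place of hydrogen on an aromatic carbon, and the step was a 1.9-fold lower number from compound 1 to compound 2 (0.29 log units; within the scatter). Compound 3, with structure `COc1cc(OC)cc(-c2nnc(SCCn3c([N+](=O)[O-])cnc3C)o2)c1`, gives 12800 nM in this assay; its value and that of compound 2 lie within the scatter of each other, so nothing can be said about which is the stronger. The difference between the core of compound 3 and the core of compound 1 is not broken down here.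

Compound 4, with structure `COc1cc(-c2nnc(SCCn3c([N+](=O)[O-])cnc3C)o2)cc(OC)c1OC`, has not yet been measured in this assay. Its difference from compound 3 is methoxy in place of hydrogen on an aromatic carbon. Within the data shown here, this is the same kind of change as the one from compound 1 to compound 2, but the surroundings differ: in compound 4 the entering methoxy sits ortho to two methoxy groups and para to a large group, whereas in compound 2 it sits only para to a large group.

Because the earlier step was a 1.9-fold lower number from compound 1 to compound 2 (0.29 log units; within the scatter), the estimated step from compound 3 to compound 4 in this assay is a 1.6-fold lower number from compound 3 to compound 4 (0.20 log units; within the scatter), and the uncertainty is wide since the surroundings are not the same. Compound 4 is expected to give about 8000 nM in this assay, with a likely range from 3000 nM to 25000 nM.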

Compound 4, half-maximal inhibitory concentration: 30600 nM
Compound 4: the middle estimate sits 3.8-fold (0.58 log units) below what was measured; measured number outside the range, above it.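

In this assay, placing one more methoxy on the aromatic ring of compound 3 gave a 2.4-fold higher number from compound 3 to compound 4 (0.38 log units; beyond the scatter), a modest step towards a weaker inhibitor, so the gain hinted at by the earlier change did not appear here. Set side by side, the two steps differ by more than repeated measurement would explain, so in this series the effect of this methoxy cannot simply be carried from one core to another: the same change on two cores in this assay, a 1.9-fold lower number (0.29 log units; within the scatter) from compound 1 to compound 2 and a 2.4-fold higher number (0.38 log units; beyond the scatter) from compound 3 to compound 4, 4.6-fold (0.66 log units) apart, beyond the scatter of two such steps

Among these compounds, this is still only one comparison of two steps, and the earlier step on its own lies within the scatter, so it does not show that methoxy reliably strengthens one core and weakens the other, nor does it establish why the steps differ, since the entering methoxy sits ortho to two methoxy groups in compound 4 and has no such neighbours in compound 2.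

The compounds shown leave open whether a different group in that same place, such as a hydroxyl, an ethoxy or a fluorine, would follow the methoxy result. They also leave open whether a longer chain between the sulfur and the nitroimidazole would alter how the ring substituents act.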